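Benzoyl in Place of Acetyl on a Thioether Lactone

The source may report more compounds than this note shows. Statements on the series, on what has been measured and on what is new or still open speak of the compounds shown alone.

Compound 1 `C=C1C(=O)O[C@@H]2CC(C)=C([C@@H](C)CCCOC(C)=O)[C@@H](OC(=O)c3ccc(F)cc3)[C@H]12` is measured in a functional assay on HCT-116 cells (Homo sapiens) for cytotoxicity, read by sulforhodamine B assay, with a stated time of 72 h (on this read-out higher numbers stand for weaker inhibition and lower numbers for stronger inhibition), where compound 1 gives 14900 nM. Compound 2 `CC(=O)OCCC[C@H](C)C1=C(C)C[C@H]2OC(=O)C(CSCCO)[C@H]2[C@@H]1OC(C)=O` keeps the acetylated side chain but carries a thioether-bearing lactone and an acetyl ester on its core. In this assay compound 2 reaches only > 100000 nM, which is a limit of the measurement rather than a number. This is the limit of > 100000 nM in this assay, at which 1 of the 2 values shown sits. Compound 3 `CC(=O)OCCC[C@H](C)C1=C(C)C[C@H]2OC(=O)C(CSCCO)[C@H]2[C@@H]1OC(=O)c1ccccc1` is the unmeasured partner of compound 2, and the change between them is phenyl in place of methyl on a carbonyl carbon. Among the compounds with values here, no measured pair shows this exact change, so the expectation rests on the limit of compound 2 alone. The expected step is an at least 1.4-fold lower number from compound 2 to compound 3 (0.15 log units; that floor lies within the scatter), a move toward stronger inhibition that may not clear the scatter. Compound 3 is therefore estimated at 70000 nM, within a range from 20000 nM to 300000 nM.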

Compound 3, half-maximal inhibitory concentration: > 100000 nM
Compound 3 gave a limit, no number; the forecaster's own chance of this, stated with the estimate: 55%; middle value at least 1.4-fold (0.15 log units) from the limit.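

In this assay compound 3 gives > 100000 nM as a limit and not a number. Within the data shown here, no step from compound 2 to compound 3 can be read, because both compounds stop at the same limit: the limit of > 100000 nM in this assay, at which 2 of the 3 values shown sit. The compounds shown leave open whether benzoyl in place of acetyl changes the result for this pair at all.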